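The source may hold more compounds than are shown below. What is called first, only, known or untested is meant among the compounds shown, and "the series" means these compounds.

Of the compounds shown here, two have been measured in an assay on CHO-K1 cells for displacement of a labelled ligand from adenosine receptor A1 (Homo sapiens), read by scintillation counting, with a stated time of 60 min, tested at 1 uM; on this read-out higher numbers stand for more inhibition at the one concentration tested (going by the name of the read-out) and lower numbers for less inhibition. Compound 1 `Nc1nc(N/N=C/c2ccc(N(c3ccccc3)c3ccccc3)cc2)nc2c1ncn2[C@@H]1O[C@H](CO)[C@@H](O)[C@H]1O` gives 0%. Compound 2 `Nc1nc(N/N=C/c2ccc(Cl)c(C(F)(F)F)c2)nc2c1ncn2[C@@H]1O[C@H](CO)[C@@H](O)[C@H]1O` gives 11%, the higher of the two numbers, and its gap to compound 1 lies beyond the scatter. Compound 3 `CSCC/C=N/Nc1nc(N)c2ncn([C@@H]3O[C@H](CO)[C@@H](O)[C@H]3O)c2n1` is not yet measured; it differs from compound 2 by 2-(methylsulfanyl)ethyl in place of 4-chloro-3-(trifluoromethyl)phenyl on a carbon with a double bond to nitrogen. Within the data shown here, no measured step of this kind exists, so no change beyond the scatter is expected in this assay, with a small downward drift judged somewhat more likely than an upward one. Compound 3 is therefore estimated at 5%, within -5% to 18%. This amounts to an expected step of a number 6 percentage points lower from compound 2 to compound 3 (within the scatter).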

Compound 3, a percentage reported as inhibition, at one concentration (the size of the read-out at that concentration, not a potency): 0%
The estimate for compound 3 lay 5 percentage points above the measured number; measured number inside the range.
By their numbers in this assay, from the lowest: compounds 1 and 3 (each within the scatter of the next); then compound 2.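

Among these compounds, the change from 4-chloro-3-(trifluoromethyl)phenyl to 2-(methylsulfanyl)ethyl on a carbon with a double bond to nitrogen gives a number 11 percentage points lower from compound 2 to compound 3 (beyond the scatter) in this assay and is the only measured step at this position. The group on this carbon therefore has a modest effect on the read-out, though this rests on a single pair. No supporting data on hand account for this step.

A plain phenyl would help separate the contribution of the ring from that of the chlorine and trifluoromethyl. Going by these compounds, an amine, a carboxylic acid or a longer chain on this carbon also remains open.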